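Swapping the Ester Group on a Furan-3-yl Core

This account rests on a few compounds, and the source may have more. Where it says the series, first, only, none or still open, it means among the compounds named here.

The measured compounds:
Compound 1 `CCC(C)OC(=O)C1=C(C)NC(=O)NC1c1ccco1` gives 84.3 nM in an assay on membranes from HEK293 cells for displacement of a labelled ligand from adenosine receptor A2b (Homo sapiens), read by scintillation counting, with a stated time of 30 min; a higher number here means a weaker inhibitor, a lower number a stronger inhibitor.
Compound 2 `CC1=C(C(=O)OC2CCC2)C(c2ccco2)NC(=O)N1` gives 95.1 nM in this assay.
Compound 3 `CCC(C)OC(=O)C1=C(C)NC(=O)NC1c1ccoc1` gives 201 nM in this assay.

Compound 4 `CC1=C(C(=O)OC2CCC2)C(c2ccoc2)NC(=O)N1` has not yet been measured. It differs from compound 3 in one place: cyclobutyl in place of sec-butyl on an oxygen next to a carbonyl group. This same change has already been tried once, since compound 2 differs from compound 1 in the same place by cyclobutyl in place of sec-butyl on an oxygen next to a carbonyl group, and that step gave a 1.1-fold higher number from compound 1 to compound 2 (0.05 log units; within the scatter). The two cores differ in how the furan is attached: compound 3 differs from compound 1 by furan-3-yl in place of furan-2-yl on a saturated ring carbon, and that step gave a 2.4-fold higher number from compound 1 to compound 3 (0.38 log units; beyond the scatter). Compound 3 thus gives the highest number of the three measured compounds.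

Because the earlier version of this change gave a 1.1-fold higher number from compound 1 to compound 2 (0.05 log units; within the scatter), the step expected for compound 4 is similarly small, a 1.1-fold higher number from compound 3 to compound 4 (0.04 log units; within the scatter). On that basis compound 4 is estimated to give about 220 nM in this assay. The estimate for compound 4 runs from 110 nM to 440 nM, allowing for the usual scatter of repeated measurements.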

Compound 4, inhibition constant: 307 nM
For compound 4 the middle estimate is 1.4-fold (0.14 log units) below the measured one; measured number inside the range.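

Putting cyclobutyl in place of sec-butyl on the oxygen next to a carbonyl group gives a 1.5-fold higher number from compound 3 to compound 4 (0.18 log units; within the scatter) in this assay, and this small step carries over between the furan-2-yl and furan-3-yl compounds: the same change on two cores in this assay, a 1.1-fold higher number (0.05 log units; within the scatter) from compound 1 to compound 2 and a 1.5-fold higher number (0.18 log units; within the scatter) from compound 3 to compound 4, 1.4-fold (0.13 log units) apart, within the scatter of two such steps

The furan change also carries over from the sec-butyl to the cyclobutyl compounds, here as a 3.2-fold higher number from compound 2 to compound 4 (0.51 log units; beyond the scatter), so the two changes appear to act independently in these four compounds: the same change on two cores in this assay, a 2.4-fold higher number (0.38 log units; beyond the scatter) from compound 1 to compound 3 and a 3.2-fold higher number (0.51 log units; beyond the scatter) from compound 2 to compound 4, 1.4-fold (0.13 log units) apart, within the scatter of two such steps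

Among the compounds shown here, this agreement rests on only two pairs for each change, so it does not show that either step would stay the same on another core, nor does it explain why the furan attachment matters.

The compounds shown leave open how a longer chain, such as n-hexyl, or a phenyl group on the same oxygen would affect the number in this assay. They also leave open whether a thiophene or a phenyl ring in place of the furan would follow the same additive pattern.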